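Three nitroimidazole amides and an unmeasured fourth

The source may report more compounds than this note shows. Statements on the series, on what has been measured and on what is new or still open speak of the compounds shown alone.

Compound 1, `Cn1c([N+](=O)[O-])cnc1C(=O)NCc1ccccn1`, gives in a toxicity assay on HepG2 cells (Homo sapiens) for inhibition, read by resazurin assay, with a stated time of 24 h (a higher number here means that more compound is tolerated, a lower number that less compound is tolerated), a value of > 100000 nM, which is a limit of the assay.
Compound 2, `CN(C)C(=O)c1ncc([N+](=O)[O-])n1C`, gives in this assay a value of > 100000 nM, also a limit.
Compound 3, `O=C(NCc1ccccn1)c1ncc([N+](=O)[O-])[nH]1`, gives in this assay a value of > 100000 nM, again a limit.

The change from compound 1 to compound 3 is hydrogen in place of methyl on an aromatic nitrogen, and it produced a step that the two limits leave unreadable from compound 1 to compound 3. All that can be said rests on (the limit of > 100000 nM in this assay, at which 3 of the 3 values shown sit). Compound 4, `CN(C)C(=O)c1ncc([N+](=O)[O-])[nH]1`, is not yet measured; it differs from compound 2 by hydrogen in place of methyl on an aromatic nitrogen, the same kind of change, though here the ring atom bears a group of 5 heavy atoms rather than a large group. The difference between the cores of compound 1 and compound 2 is not broken down here. The step expected from compound 2 to compound 4 is a number no higher from compound 2 to compound 4 (the limit leaves the size open), small because the matching change gave a step that the two limits leave unreadable from compound 1 to compound 3. Compound 4 is therefore expected to give about 100000 nM in this assay, most likely once more as a limit.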

Compound 4, half-maximal cytotoxic concentration: > 100000 nM
Compound 4: no number, only a limit (the forecaster's own chance of this, stated with the estimate: 85%); the middle value lies on the limit itself.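

No step can be read between compound 2 and compound 4, since both give only a limit: the limit of > 100000 nM in this assay, at which 4 of the 4 values shown sit.

The compounds shown leave open how far any of them lies past that limit in this assay, and so whether hydrogen in place of methyl on an aromatic nitrogen changes anything.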